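A few compounds are considered here, and "the series" means these few. Any claim that something is new, unique, unknown or untested is made for them only; others in the source may bear on it.

Measured in a functional assay on the whole organism with Mus musculus as the target, in the maximal electroshock model; on this read-out lower numbers stand for an effect already at smaller amounts and higher numbers for an effect only at larger amounts of compound:
Compound 1 `Cc1cc2nc(O)c(O)nc2c([N+](=O)[O-])c1C` gives 2.6 mg/kg
Compound 2 `CCc1cc2nc(O)c(O)nc2c([N+](=O)[O-])c1Cl` gives 4.5 mg/kg

In this assay compound 2 stands at 4.5 mg/kg and lies within the scatter of compound 1, so the two numbers cannot be told apart. Compound 3 `Cc1cc2nc(O)c(O)nc2c([N+](=O)[O-])c1Cl` has yet to be measured. It differs from compound 2 by a single change (hydrogen in place of methyl on a saturated chain carbon bound to an aromatic carbon): hydrogen in place of methyl on a saturated chain carbon bound to an aromatic carbon, which reads as ethyl to methyl. For the measured compounds named here, no measured pair differs in one place only, so the data give no direct size for this change. In this assay no step beyond the scatter is expected, in either direction. The expected step of a 1.3-fold lower number from compound 2 to compound 3 (0.11 log units; within the scatter) is small. For compound 3 the estimated value is 3.5 mg/kg with 1.6 mg/kg to 7.5 mg/kg as its expected range.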

Compound 3, dose for half-maximal effect: 1.9 mg/kg
For compound 3 the middle estimate is 1.8-fold (0.27 log units) above the measured one; measured number inside the range.
By their numbers in this assay, from the lowest: compounds 3, 1 and 2 (each within the scatter of the next, the first and the last beyond it).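

In this assay, going from ethyl to methyl on a saturated chain carbon bound to an aromatic carbon gives a 2.4-fold lower number from compound 2 to compound 3 (0.37 log units; beyond the scatter) and so provides the first direct size for this change, a modest one beyond the scatter. Chloro in place of methyl on an aromatic carbon gives a 1.4-fold lower number from compound 1 to compound 3 (0.14 log units; within the scatter) and stays within the scatter, so this read-out does not separate these two groups at that place. Nothing available here accounts for either step.

From the compounds shown here alone, with only ethyl and methyl compared on the chain, it remains open whether a propyl group would continue the step seen on going from ethyl to methyl. Going by these compounds, it also remains open how a fluoro, bromo or methoxy group on the aromatic carbon now bearing chloro would compare.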